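Aryl ether thiosemicarbazones: lipophilicity notes, compound 4

A few compounds are considered here, and "the series" means these few. Any claim that something is new, unique, unknown or untested is made for them only; others in the source may bear on it.

Measured so far in a physicochemical assay for lipophilicity, in phosphate buffer, measured as octanol-water partition, with a stated time of 24 h; a lower number here means a more polar compound, a higher number a more lipophilic compound:
compound 1 `Fc1ccc(NC(=S)N/N=C/c2ccc(Oc3ccc(F)cc3)cc2)cc1` gives 5.19
compound 2 `O=[N+]([O-])c1ccc(Oc2ccc(/C=N/NC(=S)Nc3ccc(Cl)cc3)cc2)cc1` gives 5.52
compound 3 `Fc1ccc(NC(=S)N/N=C/c2ccc(Oc3ccc4ccccc4c3)cc2)cc1` gives 6.2

Compound 3 stands highest of the three numbers in this assay. Its nearest neighbour is compound 2, whose number lies lower by a margin beyond the scatter; compound 1 lies lower still, also beyond the scatter. Within the data shown here, the one single-point step among the measured compounds is a number 1.01 log units higher from compound 1 to compound 3 (beyond the scatter), a large rise.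

Compound 4 `O=[N+]([O-])c1ccc(Oc2ccc(/C=N/NC(=S)Nc3ccc(F)cc3)cc2)cc1` is not yet measured in this assay. It differs from compound 3 in one place: 4-nitrophenyl in place of naphthalen-2-yl on an oxygen on an aromatic ring. The change undoes the naphthalen-2-yl group that carried the large rise from compound 1 to compound 3, so a fall of comparable size is expected from compound 3 to compound 4. Compound 2 carries the same 4-nitrophenyl group on the oxygen and gives 5.52; compound 1 carries the same 4-fluorophenyl thiourea end and gives 5.19. Compound 4 is therefore expected to land in this assay near those two numbers, at 5.3, with a likely range from 4.9 to 5.7. This estimate means a step of a number 0.90 log units lower from compound 3 to compound 4 (beyond the scatter), downward and beyond the scatter.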

Compound 4, partition coefficient: 4.89
Compound 4: middle estimate off by 0.41 log units, on the high side; measured number outside the range, below it.
By their numbers in this assay, from the lowest: compounds 4 and 1 (each within the scatter of the next); then compound 2; then compound 3.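

In this assay, the group on the oxygen now has three members, and naphthalen-2-yl stands apart from both single-ring groups: 4-nitrophenyl in its place gives a number 1.31 log units lower from compound 3 to compound 4 (beyond the scatter), while the pair carrying 4-fluorophenyl and 4-nitrophenyl, with nitro in place of fluoro on an aromatic carbon, gives a number 0.30 log units lower from compound 1 to compound 4 (within the scatter), so these two groups are not separated here. Among these compounds, the other end of the molecule, which no earlier step had touched, also moves this read-out: fluoro in place of chloro on an aromatic carbon, with 4-nitrophenyl held on the oxygen, gives a number 0.63 log units lower from compound 2 to compound 4 (beyond the scatter), a modest step set against the large one at the oxygen. Nothing available on these compounds accounts for the size or direction of any of these steps.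

Among the compounds shown here, whether the fluoro and chloro step keeps its size with naphthalen-2-yl on the oxygen remains open, as that halogen pair is seen only with 4-nitrophenyl in place. Also open is how this assay responds when an amine, a carboxylic acid or a longer alkyl chain stands on the aromatic ring attached to the oxygen, since the compounds shown carry only fluoro, nitro or a fused benzene ring there.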